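Replacing a nitrile-bearing ring on the sulfonyl group

The source may report more compounds than this note shows. Statements on the series, on what has been measured and on what is new or still open speak of the compounds shown alone.

Measured so far:
compound 1 `O=S(=O)(c1ccc(F)c(F)c1)c1cnc2cc(F)ccc2c1-c1ccc(Cl)cc1`: 0.01 mL/min
compound 2 `N#Cc1cccc(S(=O)(=O)c2cnc3cc(F)ccc3c2-c2cccc(F)c2)c1`: 0.78 mL/min

Compound 1 and compound 2 were tested in an ADME assay on microsomes from liver (Homo sapiens) for metabolic stability, tested at 2.5 uM; a lower number here means slower removal, a higher number faster removal of the compound. Compound 2 has the higher of the two numbers; compound 1 sits far below it, a gap well beyond the usual scatter. The two differ in two places, so neither place alone can be credited with the gap.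

Compound 3 `O=S(=O)(c1ccc(F)c(F)c1)c1cnc2cc(F)ccc2c1-c1cccc(F)c1` has not yet been measured in this assay. It differs from compound 2 in one place: 3,4-difluorophenyl in place of 3-cyanophenyl on a sulfonyl sulfur. With this change, compound 3 carries the same 3,4-difluorophenyl on the sulfonyl sulfur as compound 1, while keeping the 3-fluorophenyl of compound 2 on the core. Its value is therefore expected to lie between those of the two measured compounds.

For compound 3 a decrease is expected, with the step from compound 2 estimated at a 6.5-fold lower number from compound 2 to compound 3 (0.81 log units; beyond the scatter), beyond the scatter. The value of compound 3 in this assay is estimated at 0.12 mL/min, within a range of 0.02 mL/min to 0.7 mL/min.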

Compound 3, intrinsic clearance in a liver preparation (reported as CLH), per the amount of preparation that the assay uses: 0.6 mL/min
The estimate for compound 3 lay 5.0-fold (0.70 log units) below the measured number, and the stated range covers the measured number.
By their numbers in this assay, from the lowest: compound 1; then compounds 3 and 2 (each within the scatter of the next).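

In this assay, the exchange on the sulfonyl sulfur alone, 3,4-difluorophenyl in place of 3-cyanophenyl, gives a 1.3-fold lower number from compound 2 to compound 3 (0.11 log units; within the scatter) and so cannot be told from repeat variation. With the same 3,4-difluorophenyl on the sulfonyl sulfur, 3-fluorophenyl in place of 4-chlorophenyl on an aromatic carbon gives a 60-fold higher number from compound 1 to compound 3 (1.78 log units; beyond the scatter) in the same assay, which separates the large gap between compound 1 and compound 2 from the sulfonyl exchange and places it with the exchange on the aromatic carbon. Nothing available explains why this second exchange has so large an effect.

As far as these compounds go, the exchange on the aromatic carbon has been read only with 3,4-difluorophenyl on the sulfonyl sulfur, so whether 4-chlorophenyl would give a similarly low number alongside 3-cyanophenyl remains open. From the compounds shown here alone, it also remains open how a short alkyl chain or an amine-bearing ring on the sulfonyl sulfur would behave, and whether the chlorine of compound 1 or its place on the ring accounts for the step.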